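A few compounds are considered here, and "the series" means these few. Any claim that something is new, unique, unknown or untested is made for them only; others in the source may bear on it.

Measured so far:
Compound 1, `Cn1c(Cc2nn(C)c(=O)c3ccccc23)nnc1SCCCCCCCC(=O)Nc1ccc(Cl)cc1Cl`, gives 190 nM in an assay on NK92 cells for inhibition of interleukin-15 (Homo sapiens), read by AlphaScreen, with stated times of 30 min and 1 h; on this read-out higher numbers stand for weaker inhibition and lower numbers for stronger inhibition.
Compound 2, `CCOC(CCn1c(Cc2nn(C)c(=O)c3ccccc23)nnc1SCC(=O)Nc1ccc(Cl)cc1Cl)OCC`, reaches only the assay limit, > 30000 nM.
Compound 3, `Cn1nc(Cc2nnc(SCCCCCCCC(=O)Nc3ccc(Cl)cc3Cl)[nH]2)c2ccccc2c1=O`, gives 280 nM.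

Compound 2 thus stands apart from compound 1 and compound 3 with no number at all, only a limit (the limit of > 30000 nM in this assay, at which 1 of the 3 values shown sits). For the measured compounds named here, the only measured step, a 1.5-fold higher number from compound 1 to compound 3 (0.17 log units; within the scatter), concerns a different part of the shared core and says nothing about the chain on the aromatic nitrogen. Compound 4, `Cn1nc(Cc2nnc(SCC(=O)Nc3ccc(Cl)cc3Cl)n2CCCO)c2ccccc2c1=O`, differs from compound 2 in that change alone: hydroxymethyl in place of diethoxymethyl on a saturated chain carbon, two bonds along the chain from an aromatic nitrogen. Going by the values given here, no measured pair bears on this change, so the expectation rests on compound 2 alone. The expected step is an at least 1.5-fold lower number from compound 2 to compound 4 (0.17 log units; that floor lies within the scatter). Compound 4 is therefore estimated at 20000 nM, within 3000 nM to 60000 nM, with a limit again quite possible.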

Compound 4, half-maximal inhibitory concentration: > 30000 nM
Compound 4 ended at the assay's limit; the forecaster's own chance of this, stated with the estimate: 55%; at least 1.5-fold (0.17 log units) between middle value and limit.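

Compound 2 and compound 4 both end at a limit rather than a number, so the step between them cannot be read: the limit of > 30000 nM in this assay, at which 2 of the 4 values shown sit.

Going by these compounds, whether 3-hydroxypropyl in place of 3,3-diethoxypropyl changes inhibition at all remains open.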